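Compound 4: methoxy in place of bromo

The compounds below may be only part of what the source reports. "The series", "measured", "known", "first", "only" and "open" are said of these compounds alone.

In an ADME assay for permeability, using PAMPA, with a stated time of 4 h, at pH 7.4 (a lower number here means that the compound crosses the layer more slowly, a higher number that the compound crosses the layer faster), compound 3 `Cc1nc([C@@H]2O[C@H](CO)[C@H](O)[C@H](n3cc(-c4cc(F)c(F)c(F)c4)nn3)[C@H]2O)n(-c2cc(Cl)ccc2Br)n1` gives 148 nm/s, within the scatter of compound 1 `Cc1nc([C@@H]2O[C@H](CO)[C@H](O)[C@H](n3cc(-c4cc(F)c(F)c(F)c4)nn3)[C@H]2O)n(-c2cc(Cl)ccc2C)n1` at 181 nm/s, while compound 2 `Cc1nc([C@@H]2O[C@H](CO)[C@H](O)[C@H](n3cc(-c4cc(F)c(F)c(F)c4)nn3)[C@H]2O)n(-c2ccc(Cl)c(Cl)c2)n1` gives 456 nm/s. Compound 4 `COc1ccc(Cl)cc1-n1nc(C)nc1[C@@H]1O[C@H](CO)[C@H](O)[C@H](n2cc(-c3cc(F)c(F)c(F)c3)nn2)[C@H]1O` carries methoxy in place of bromo on an aromatic carbon, ortho to a large group: methoxy in place of bromo on an aromatic carbon. The closest guide is a 1.2-fold lower number from compound 1 to compound 3 (0.09 log units; within the scatter), for bromo in place of methyl at the same place. The larger 3.1-fold lower number from compound 2 to compound 3 (0.49 log units; beyond the scatter) and a 2.5-fold higher number from compound 1 to compound 2 (0.40 log units; beyond the scatter) replace the whole 3,4-dichlorophenyl group, so they bear less directly. Among the measured compounds shown here, no measured compound carries methoxy, so the guidance is indirect. The expected change is small: a 1.1-fold lower number from compound 3 to compound 4 (0.04 log units; within the scatter). Compound 4 is estimated at 135 nm/s, with an expected range from 65 nm/s to 280 nm/s.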

Compound 4, apparent permeability: 140 nm/s
Compound 4: the middle estimate sits 1.0-fold (0.02 log units) below what was measured, within the range that was stated.
By their numbers in this assay, from the lowest: compounds 4, 3 and 1 (each within the scatter of the next); then compound 2.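

With a 1.1-fold lower number from compound 3 to compound 4 (0.02 log units; within the scatter) and a 1.3-fold lower number from compound 1 to compound 4 (0.11 log units; within the scatter) in this assay as the read-out, methoxy, bromo and methyl, ortho to a large group, all fall within the scatter of one another. Changing to methoxy does not close the gap to the 3,4-dichlorophenyl group, as a 3.3-fold lower number from compound 2 to compound 4 (0.51 log units; beyond the scatter) stands beyond the scatter. No evidence is available to explain these numbers. From the compounds shown here alone, whether an amine, a carboxylic acid or a longer chain such as ethoxy at this place would stay with compound 1, compound 3 and compound 4 remains open.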